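Methoxy to Ethoxy, Repeated on a Stronger Compound

The source may report more compounds than this note shows. Statements on the series, on what has been measured and on what is new or still open speak of the compounds shown alone.

Measured so far:
compound 1, `COc1cc(OC)c(/C=C/S(=O)(=O)Cc2cnc(OC)cn2)c(OC)c1`: 950 nM
compound 2, `CCOc1cnc(CS(=O)(=O)/C=C/c2c(OC)cc(OC)cc2OC)cn1`: 1280 nM
compound 3, `COc1ccc(NS(=O)(=O)/C=C/c2c(OC)cc(OC)cc2OC)cc1`: 10 nM

In a functional assay on HCT-116 cells (Homo sapiens) for antiproliferative activity, read by MTT assay, with a stated time of 72 h (a higher number here means a weaker inhibitor of growth, a lower number a stronger inhibitor of growth), compound 1 gives 950 nM and compound 2 gives 1280 nM; the change between them is methyl in place of hydrogen on a saturated chain carbon bound to an oxygen on an aromatic ring and the step is a 1.3-fold higher number from compound 1 to compound 2 (0.13 log units; within the scatter). Compound 3 gives 10 nM in this assay; the difference between its core and that of compound 1 is not broken down here. Compound 4, `CCOc1ccc(NS(=O)(=O)/C=C/c2c(OC)cc(OC)cc2OC)cc1`, differs from compound 3 by methyl in place of hydrogen on a saturated chain carbon bound to an oxygen on an aromatic ring, the same change at the same place. Because a 1.3-fold higher number from compound 1 to compound 2 (0.13 log units; within the scatter) stayed within the scatter, the step from compound 3 to compound 4 is expected to be small as well, estimated as a 1.3-fold higher number from compound 3 to compound 4 (0.11 log units; within the scatter). Compound 4 is therefore expected to give about 13 nM in this assay, estimated between 5 nM and 40 nM.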

Compound 4, concentration for 50% growth inhibition: 350 nM
Beside the measured number, compound 4's estimate is 27-fold (1.43 log units) below it; the whole stated range lies below it.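

In this assay the change from methoxy to ethoxy gives a 35-fold higher number from compound 3 to compound 4 (1.54 log units; beyond the scatter) on this core, so the small step seen on the earlier pair did not carry over. The two steps differ clearly between the two cores: the same change on two cores in this assay, a 1.3-fold higher number (0.13 log units; within the scatter) from compound 1 to compound 2 and a 35-fold higher number (1.54 log units; beyond the scatter) from compound 3 to compound 4, 26-fold (1.41 log units) apart, beyond the scatter of two such steps. This shows that in these two pairs the size of the step depends on the core; it does not show why, and two pairs set no rule for any other core in the series.

The compounds shown leave open how a longer chain, such as propoxy, would behave on the core of compound 3. They also leave open whether a hydroxyl group or an amine in place of the ethoxy group would give a number closer to that of compound 3.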